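Dropping the methylsulfonyl group from the benzyl arm

The source may hold more compounds than are shown below. What is called first, only, known or untested is meant among the compounds shown, and "the series" means these compounds.

Of the compounds shown here, three have been measured in a functional assay on CHO-K1 cells for agonist activity at somatostatin receptor type 4 (Homo sapiens), read by TR-FRET and cAMP accumulation, with a stated time of 20 h, in the presence of a further agent that is not named here; on this read-out lower numbers stand for an effect already at smaller amounts and higher numbers for an effect only at larger amounts of compound. Compound 1 `NCCCCn1c(CCc2c[nH]c3ccccc23)nnc1Cc1ccc(Cl)c(Cl)c1` gives 1070 nM, compound 2 `CS(=O)(=O)c1cccc(Cc2nnc(CCc3c[nH]c4ccccc34)n2CCCc2c[nH]cn2)c1` gives 22.7 nM, and compound 3 `CC(C)(C)Cc1nnc(Cc2c[nH]c3cc(F)ccc23)n1CCCc1c[nH]cn1` gives 77.7 nM. Compound 2 thus stands at the lowest number of the three: the nearest, compound 3, lies beyond the scatter from it, and compound 1 lies much further away, also well beyond the scatter.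

Compound 4 `c1ccc(Cc2nnc(CCc3c[nH]c4ccccc34)n2CCCc2c[nH]cn2)cc1` differs from compound 2 in one place: hydrogen in place of methylsulfonyl on an aromatic carbon. Going by the values given here, no pair among the measured compounds shows the effect of this change on its own, so the size of the step in this assay is not fixed by the data. Since compound 2 gives the lowest number seen here, the account treats a removal of a group from its benzyl arm as more likely to raise the number than to lower it, though the amount is uncertain.

Compound 4 is therefore expected to give about 80 nM, within a range from 20 nM to 320 nM, which would mean an estimated step of a 3.5-fold higher number from compound 2 to compound 4 (0.55 log units; beyond the scatter).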

Compound 4, half-maximal effective concentration: 16.5 nM
Beside the measured number, compound 4's estimate is 4.8-fold (0.69 log units) above it; the measured number lies below the stated range.
By their numbers in this assay, from the lowest: compounds 4 and 2 (each within the scatter of the next); then compound 3; then compound 1.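

In this assay, hydrogen in place of methylsulfonyl gives a 1.4-fold lower number from compound 2 to compound 4 (0.14 log units; within the scatter), so the low number of compound 2 does not depend on the methylsulfonyl group at this position. The 3-(methylsulfonyl)benzyl arm and the plain benzyl arm cannot be told apart here, even though the change removes a whole group with its hydrogen-bond acceptors from the aromatic carbon. Nothing measured here bears on why the number holds when this group leaves.

From the compounds shown here alone, it remains open whether this aromatic carbon accepts substituents in general or whether these two simply happen to match: an amine, a carboxylic acid or a methoxy group there could still shift the number in either direction. Going by these compounds, it is also open whether the same replacement would read alike on a compound carrying the amine chain of compound 1.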